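Swapping benzyl for 2-bromophenyl on compound 1

A few compounds are considered here, and "the series" means these few. Any claim that something is new, unique, unknown or untested is made for them only; others in the source may bear on it.

In a toxicity assay on cells (Macrophage, Mus musculus, strain BALB/c) for cytotoxicity, read by MTT assay (on this read-out higher numbers stand for weaker inhibition and lower numbers for stronger inhibition), compound 1 `C=CCOc1cc(OC)c(C(=O)/C=C/Cc2ccccc2)c(OCC=C)c1` gives 14800 nM. Compound 3 `COc1cc(O)cc(O)c1C(=O)/C=C/c1ccc(C)cc1` gives 16500 nM, and this lies within the usual scatter of the value for compound 1, so the two cannot be told apart. Compound 2 `COCc1cc(O)c(C(=O)/C=C/c2cc(OC)c(OC)c(OC)c2)c(OC)c1` gives 133000 nM, which is well beyond the scatter from the value for compound 1. Compound 1 therefore sits at the low end of the three numbers, level with compound 3 and far from compound 2.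

Compound 4 `C=CCOc1cc(OC)c(C(=O)/C=C/c2ccccc2Br)c(OCC=C)c1` has not yet been measured. It keeps the core of compound 1 and changes one group, with 2-bromophenyl in place of benzyl on a double-bonded chain carbon bound to a double-bonded chain carbon.

For the measured compounds named here, no two measured compounds differ in only one place, so the data give no direct guide to the size of this step. The best anchor is compound 1 itself at 14800 nM, since compound 4 shares its core. In this assay, the expected step is none beyond the scatter, and the estimate is a 1.1-fold higher number from compound 1 to compound 4 (0.03 log units; within the scatter). The range stays wide because compound 2 at 133000 nM shows how far values can spread among these few compounds. Compound 4 is expected at about 16000 nM, with an estimated range from 5000 nM to 50000 nM.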

Compound 4, half-maximal inhibitory concentration: 5400 nM
Beside the measured number, compound 4's estimate is 3.0-fold (0.47 log units) above it; the measured number falls inside the stated range.
By their numbers in this assay, from the lowest: compound 4; then compounds 1 and 3 (each within the scatter of the next); then compound 2.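

In this assay, putting 2-bromophenyl in place of benzyl gives a 2.7-fold lower number from compound 1 to compound 4 (0.44 log units; beyond the scatter) and so shows that this place, on a double-bonded chain carbon bound to a double-bonded chain carbon, responds to a change of group. The earlier compounds shown here could not show this, as no two of them differ in only one place. The change is also more than a swap of one atom: both groups have 7 heavy atoms and one six-membered aromatic ring of carbon only, but cut one bond further out it reads 3-phenylprop-1-en-1-yl to 2-(2-bromophenyl)ethenyl, so a bromine enters and the chain changes too, and no measurement shown here says which of the two matters.

A plain phenyl or a 2-chlorophenyl on the same ethenyl chain would be needed to separate the part played by the bromine from that of the chain. From the compounds shown here alone, how this place would respond to a quite different group, such as an amine or a carboxylic acid on the ring, also remains open.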